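Swapping the benzyl substituent: compound 3 to compound 4

The source may hold more compounds than are shown below. What is called first, only, known or untested is meant among the compounds shown, and "the series" means these compounds.

Measured compounds:
compound 1 `Cc1ccc(Cn2cc(COc3ccc4c(=O)ccoc4c3)nn2)cc1` — 68500 nM
compound 2 `O=c1ccoc2cc(OCc3cn(Cc4cccc(Cl)c4)nn3)ccc12` — 28400 nM
compound 3 `O=c1ccoc2cc(OCc3cn(Cc4ccccc4F)nn3)ccc12` — 36900 nM

In a functional assay on QGY7701 cells (Homo sapiens) for cytotoxicity, read by MTT assay, with a stated time of 48 h (a higher number here means a weaker inhibitor, a lower number a stronger inhibitor), compound 3 stands second highest of the three numbers; its nearest neighbour is compound 2, at a separation within the scatter, and the gap to compound 1 is also within the scatter. Compound 4 `O=c1ccoc2cc(OCc3cn(Cc4ccc([N+](=O)[O-])cc4)nn3)ccc12` differs from compound 3 by the change (4-nitrophenyl in place of 2-fluorophenyl on a saturated chain carbon bound to an aromatic nitrogen). The relevant precedents are all swaps of the phenyl substituent at the same place: a 2.4-fold lower number from compound 1 to compound 2 (0.38 log units; beyond the scatter), a 1.9-fold lower number from compound 1 to compound 3 (0.27 log units; within the scatter) and a 1.3-fold higher number from compound 2 to compound 3 (0.11 log units; within the scatter). Among the compounds with values here, only one of those steps cleared the scatter, and modestly. Within the data shown here, a 4-nitrophenyl group has no measured precedent here, so compound 4 is expected to land near compound 3, with a 1.2-fold lower number from compound 3 to compound 4 (0.09 log units; within the scatter) as the estimated step. The estimate for compound 4 in this assay is 30000 nM, with a range from 12000 nM to 80000 nM.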

Compound 4, half-maximal inhibitory concentration: > 100000 nM
Compound 4: only a limit was reported; the forecaster's own chance of this, stated with the estimate: 10%; at least 3.3-fold (0.52 log units) between middle value and limit.
By their numbers in this assay, from the lowest: compounds 2, 3 and 1 (each within the scatter of the next, the first and the last beyond it). At a limit, above all of these: compound 4.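

In this assay compound 4 gives only a limit, not a number: the limit of > 100000 nM in this assay, at which 1 of the 4 values shown sits. Even so, this is the first change at this position that separates clearly from both halogen-bearing benzyl compounds, with an at least 2.7-fold higher number from compound 3 to compound 4 (0.43 log units; beyond the scatter) and an at least 3.5-fold higher number from compound 2 to compound 4 (0.54 log units; beyond the scatter), so 4-nitrophenyl is worse here than 2-fluorophenyl or 3-chlorophenyl. Against 4-methylphenyl no such separation is shown, with an at least 1.4-fold higher number from compound 1 to compound 4 (0.16 log units; that floor lies within the scatter). On these data alone, whether an amine or a carboxylic acid on the phenyl ring would restore the numbers of compound 2 and compound 3 stays open. So does the true value of compound 4.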